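Methoxy for Fluoro on a Weakly Cytotoxic Scaffold

This account rests on a few compounds, and the source may have more. Where it says the series, first, only, none or still open, it means among the compounds named here.

Compound 2 `COc1cc(-c2nnc3n2NC(c2ccco2)C(C(=O)c2ccc(F)cc2)S3)cc(OC)c1OC` was tested in a functional assay on HepG2 cells (Homo sapiens) for cytotoxicity, read by MTT assay, with a stated time of 48 h; on this read-out lower numbers stand for stronger inhibition and higher numbers for weaker inhibition. In this assay compound 2 returned only the limit > 100000 nM, so no number is known for it. Its near relative compound 1 `COc1cc(-c2nnc3n2NC(c2ccco2)C(C(=O)c2ccc(Cl)cc2)S3)cc(OC)c1OC` gives 78600 nM in this assay. The step of an at least 1.2-fold higher number from compound 1 to compound 2 (0.10 log units; that floor lies within the scatter) is small; it rests on the limit of > 100000 nM in this assay, at which 1 of the 2 values shown sits, and so cannot be sized any further.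

Compound 3 `COc1ccc(C(=O)C2Sc3nnc(-c4cc(OC)c(OC)c(OC)c4)n3NC2c2ccco2)cc1` is not yet measured. It differs from compound 2 in one place: methoxy in place of fluoro on an aromatic carbon. Going by the values given here, no measured step here swaps fluoro for methoxy, and the one step that is known, from chloro to fluoro, sits within the scatter. Compound 3 is therefore expected to show a step that the limit leaves unreadable from compound 2 to compound 3 that does not exceed the scatter, and most likely another limit. The estimate for compound 3 in this assay is 120000 nM, within a range from 50000 nM to 300000 nM.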

Compound 3, half-maximal inhibitory concentration: > 100000 nM
Compound 3: only a limit was reported; the forecaster's own chance of this, stated with the estimate: 60%; the middle value is on the limit's open side.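

Methoxy on this aromatic carbon, like fluoro, gives no measurable value in this assay, since compound 3 also ends at a limit and not at a number. Going from chloro to methoxy gives an at least 1.2-fold higher number from compound 1 to compound 3 (0.10 log units; that floor lies within the scatter), so the change at this position can be sized only as a floor, while the step from fluoro to methoxy cannot be read at all. Of the three groups at this position, only chloro in compound 1 has a true number, and the comparison stops at the assay's ceiling: the limit of > 100000 nM in this assay, at which 2 of the 3 values shown sit.

The compounds shown leave open how far compound 2 and compound 3 lie past that limit. They also leave open whether a different group on this aromatic carbon, such as an amine or a carboxylic acid, would give a readable value clearly apart from that of compound 1.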